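A few compounds are considered here, and "the series" means these few. Any claim that something is new, unique, unknown or untested is made for them only; others in the source may bear on it.

Notes on the series. Compound 2 `CCOCCOC(=O)Nc1cc2nc(C3CCCCC3)[nH]c2cc1N(C)C` is the reference for the step under consideration. In an ADME assay on Vero cells (Chlorocebus sabaeus) for cytotoxicity, read by resazurin assay, with a stated time of 3 days (on this read-out lower numbers stand for stronger inhibition and higher numbers for weaker inhibition), compound 2 gives > 100 ug/mL, which is a limit of the assay and not a number. Compound 3 `CCOCCOC(=O)Nc1cc2nc(C3CCCCC3)[nH]c2cc1N1CCCC1` gives > 100 ug/mL in this assay, again a limit. Compound 1 `CCN(CC)c1cc2[nH]c(C3CCCCC3)nc2cc1NC(=O)c1ccc(N(C)C)cc1` gives "not determined" (no result reported) in this assay. Among the measured compounds shown here, the one measured step, a step that the two limits leave unreadable from compound 2 to compound 3, is therefore unreadable, and both measured values sit at the limit of > 100 ug/mL in this assay, at which 2 of the 3 values shown sit. Compound 4 `CN(C)c1cc2[nH]c(C3CCCCC3)nc2cc1NC(=O)c1ccc(F)cc1F` differs from compound 2 as follows: 2,4-difluorophenyl in place of 2-ethoxyethoxy on a carbonyl carbon. For the measured compounds named here, no measured step touches this position, so no direction can be read. Compound 4 is expected to stay near the limit, at an estimated 100 ug/mL with a range of 35 ug/mL to 300 ug/mL, the expected step being a number no higher from compound 2 to compound 4 (the limit leaves the size open).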

Compound 4, half-maximal inhibitory concentration: > 100 ug/mL
Compound 4 ended at the assay's limit (the forecaster's own chance of this, stated with the estimate: 65%); the middle value lies on the limit itself.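

No new step can be read from compound 2 to compound 4, as both values are limits and not numbers: the limit of > 100 ug/mL in this assay, at which 3 of the 4 values shown sit. The compounds shown leave open whether any group on the carbonyl carbon brings a value inside the measurable range.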